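Carbamoyl side chain on the chloro-core of compound 2

A few compounds are considered here, and "the series" means these few. Any claim that something is new, unique, unknown or untested is made for them only; others in the source may bear on it.

Three compounds have numbers in a functional assay on the whole organism (Tail, strain ICR) with Mus musculus as the target, in the tail flick test, with a stated time of 60 min, at a dose of 25 umol/kg by the oral route; a higher number here means a stronger effect of the compound at the dose given, a lower number a weaker effect. Compound 1 `N=C(N)NCCC[C@H](NC(=O)CN(c1ncnc2c1ncn2C1CCCCO1)C1CC1)C(=O)OCc1ccccc1` gives 52.4%. Compound 2 `CC[C@H](C)[C@H](NC(=O)CN(c1nc(Cl)nc2[nH]cnc12)C1CC1)C(=O)OCc1ccccc1` gives 40.6%, the second highest of the three: its nearest neighbour is compound 3 `NC(=O)CC[C@H](NC(=O)CN(c1ncnc2c1ncn2C1CCCCO1)C1CC1)C(=O)OCc1ccccc1` with 39.4%, a gap within the scatter, and its furthest is compound 1, which stands beyond the scatter above it.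

The next compound, compound 4 `NC(=O)CC[C@H](NC(=O)CN(c1nc(Cl)nc2[nH]cnc12)C1CC1)C(=O)OCc1ccccc1`, is unmeasured. It differs from compound 2 in one place: 2-carbamoylethyl in place of sec-butyl on a saturated chain carbon bound to an amide-type nitrogen and a carbonyl carbon. Compound 4 thus carries the same side chain as compound 3 on the core of compound 2.

For the measured compounds named here, one measured step bears on this: a number 13 percentage points lower from compound 1 to compound 3 (beyond the scatter), where the entering group of the present change also arrived, though the leaving group was a different one, and on a different core. That step was modest and downward. The separate comparison of compound 2 with compound 3, whose values lie within the scatter of each other, gives no direction of its own.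

Taken together, a small downward step is expected in this assay, a number 5.6 percentage points lower from compound 2 to compound 4 (within the scatter), with no strong case for a move beyond the scatter. The estimate for compound 4 is therefore 35%, with a range from 22% to 50%.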

Compound 4, a percentage reported as activity, at one dose (the size of the read-out at that dose, not a potency): 33.1%
Estimate against measurement, compound 4: 1.9 percentage points above, and the stated range covers the measured number.
By their numbers in this assay, from the lowest: compounds 4, 3 and 2 (each within the scatter of the next); then compound 1.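

In this assay, the exchange of sec-butyl for 2-carbamoylethyl on a saturated chain carbon bound to an amide-type nitrogen and a carbonyl carbon gives a number 7.5 percentage points lower from compound 2 to compound 4 (within the scatter). For the compounds shown here, this is the first direct comparison of 2-carbamoylethyl with a side chain that has no hydrogen-bond donors or acceptors, and on the core of compound 2 the exchange does not move the read-out beyond the usual scatter of this dose-level measurement. The series offers no measurement that accounts for the size of this step.

From the compounds shown here alone, whether the chain of compound 1, which holds the highest number of the set at 52.4%, would keep that lead on the core of compound 2 remains open. Equally open, going by these compounds, is how this chain carbon responds on that core to a carboxylic acid, a primary amine or a longer alkyl chain, and whether any of these would give a step beyond the scatter in this assay.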